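Methyl in place of fluoro: outlook for compound 3

The source may report more compounds than this note shows. Statements on the series, on what has been measured and on what is new or still open speak of the compounds shown alone.

Compound 2 `Cc1c(OC[C@@H](C)COc2ccc(F)c(C(=O)O)c2)ccc(C(=O)CC(C)(C)C)c1O` is measured in an assay for positive allosteric modulation of metabotropic glutamate receptor 3 (Rattus norvegicus) (a lower number here means that less compound is needed, a higher number that more compound is needed for the effect), at 1180 nM. Within the data shown here, the only comparator is compound 1 `Cc1c(OC[C@H](C)COc2ccc(F)c(C(=O)O)c2)ccc(C(=O)CC(C)(C)C)c1O`, which in this assay gives 651 nM. The change a 1.8-fold higher number from compound 1 to compound 2 (0.26 log units; within the scatter) lies within the scatter, and the fact that compounds 1 and 2 differ only in the configuration as drawn is all that separates the pair, so compound 2 and compound 1 stand at the two ends of the numbers without being distinguishable from each other.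

Compound 3 `Cc1ccc(OC[C@H](C)COc2ccc(C(=O)CC(C)(C)C)c(O)c2C)cc1C(=O)O` keeps the shared core and the configuration as drawn in compound 2 and carries methyl in place of fluoro on an aromatic carbon. Among the measured compounds shown here, no measured step touches this ring or this exchange; the one step on record concerns configuration only and was within the scatter, so it offers no direction for a substituent change. In this assay the expectation is therefore a step of a 1.2-fold lower number from compound 2 to compound 3 (0.07 log units; within the scatter), that is, none beyond the scatter, with the band widened for the lack of precedent. Compound 3 is expected to give 1000 nM, within 350 nM to 3000 nM.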

Compound 3, half-maximal effective concentration: > 10000 nM
Compound 3 gave a limit, no number; the forecaster's own chance of this, stated with the estimate: 5%; middle value at least 10-fold (1.00 log units) away from the limit.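

In this assay, the change from 3-carboxy-4-fluorophenyl to 3-carboxy-4-methylphenyl, on the aromatic carbon ortho to a carboxy group and para to a large group, gives the only step shown that lies beyond the scatter: an at least 8.4-fold higher number from compound 2 to compound 3 (0.92 log units; beyond the scatter). Compound 3 stands at > 10000 nM, which is a limit of the assay and not a number, so the step fixes a minimum size and no exact one: the limit of > 10000 nM in this assay, at which 1 of the 3 values shown sits. The earlier step, a 1.8-fold higher number from compound 1 to compound 2 (0.26 log units; within the scatter), concerned configuration only, whereas this one shows that the position responds to the exchange of one heavy atom for one heavy atom, with the counts of rings, hydrogen-bond donors, hydrogen-bond acceptors and net charge unchanged.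

A single exchange cannot separate the effect of adding methyl from that of losing fluoro, and chloro, methoxy or plain hydrogen at this position would help to tell the two apart. Also open, as far as these compounds go, is whether the other configuration at the saturated chain carbon would behave differently with methyl on the ring.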